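Working notes: nitrile swap on compound 2

The source may hold more compounds than are shown below. What is called first, only, known or untested is meant among the compounds shown, and "the series" means these compounds.

Compound 1 `CC(C)(O)c1ccn2c(-c3ccc(F)c(-c4cccnc4)c3)cnc2n1`: 46%
Compound 2 `CC(C)(O)c1cnn2c(-c3ccc(F)c(-c4ncc(F)cc4F)c3)cnc2n1`: 64%

In an in vivo ADME assay on the whole organism for pharmacokinetics, with Canis familiaris (Canis lupus familiaris) as the target, at a dose of 1 mg/kg (a higher number here means that a larger share of the oral dose reaches the circulation, a lower number that a smaller share of the oral dose reaches the circulation), compound 2 stands highest of the two measured compounds at 64%. Compound 1 lies lower at 46%, and the gap between them is beyond the usual scatter. These two compounds differ in more than one place, so their gap cannot be assigned to any single change.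

Compound 3 `CC(C)(O)c1cnn2c(-c3ccc(F)c(-c4ncccc4C#N)c3)cnc2n1` is derived from compound 2 by placing 3-cyanopyridin-2-yl in place of 3,5-difluoropyridin-2-yl on an aromatic carbon. Among the compounds with values here, no measured pair isolates this change, so its size in this assay is a judgement with wide margins. A small fall, not beyond the scatter, is expected. Within the data shown here, the only anchors are compound 2 at 64% and compound 1 at 46%, and a value for the new compound near or between these seems most likely.

The expected change is a number 9 percentage points lower from compound 2 to compound 3 (within the scatter). For compound 3 the estimated value is 55%, with an expected range of 35% to 73%.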

Compound 3, oral bioavailability: 99%
For compound 3 the middle estimate is 44 percentage points below the measured one; the whole stated range lies below it.
By their numbers in this assay, from the lowest: compound 1; then compound 2; then compound 3.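

In this assay the series now has its first comparison that differs in one place, and a number 35 percentage points higher from compound 2 to compound 3 (beyond the scatter). The step shows that the group at this position, ortho to a fluoro group on the six-membered aromatic ring of carbon only, can move oral bioavailability by a large margin, even though 3,5-difluoropyridin-2-yl and 3-cyanopyridin-2-yl both have 8 heavy atoms and one six-membered aromatic ring with 1 hetero atom. No measured property of either group accompanies this single pair, so the result remains an observed step without an explanation.

The change removes both fluoro groups and adds the nitrile in one move, so the compounds shown leave open how much of the step belongs to each, a question that an unsubstituted pyridin-2-yl or a 3-fluoropyridin-2-yl group would address, as would a primary amide or a methoxy group in place of the nitrile. Also open, on these data alone, is whether the step carries over to the core of compound 1, which differs from compound 2 in more than one place.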